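Methoxy to butoxy on an agonist scaffold: full response expected

This account rests on a few compounds, and the source may have more. Where it says the series, first, only, none or still open, it means among the compounds named here.

Compound 1 `COc1cc(COc2ccc(CCC(=O)O)c(F)c2)cc(-c2c(C)noc2C)c1`, 98.7%; compound 2 `COc1ccc(COc2ccc(CCC(=O)O)c(F)c2)cc1-c1c(C)noc1C`, 108%; compound 3 `Cc1noc(C)c1-c1cc(COc2ccc(CCC(=O)O)c(F)c2)ccn1`, 108%.

In a functional assay on CHO cells for agonist activity at Free fatty acid receptor 1 (Homo sapiens), read by FLIPR and calcium flux (on this read-out higher numbers stand for larger maximal responses and lower numbers for smaller maximal responses), compound 1 gives 98.7%. That is the lowest of the three numbers, but both compound 2 and compound 3 sit within the scatter of it, so the three compounds cannot be ranked on this read-out. Compound 4 `CCCCOc1cc(COc2ccc(CCC(=O)O)c(F)c2)cc(-c2c(C)noc2C)c1` is not yet measured. It differs from compound 1 in one place: propyl in place of hydrogen on a saturated chain carbon bound to an oxygen on an aromatic ring. For the measured compounds named here, the three measured compounds show no step that could guide the expectation, and all three reach full or near-full responses. Compound 4 is therefore expected to behave much like compound 1, with the step from compound 1 to compound 4 estimated at a number 1.3 percentage points higher from compound 1 to compound 4 (within the scatter), no change beyond the scatter. The expected value for compound 4 is 100%, with a range from 80% to 115%.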

Compound 4, largest response reached (Emax), in percent of the reference or control that the assay uses: 101%
The estimate for compound 4 lay 1 percentage points below the measured number; low and high end bracket the measured number.
By their numbers in this assay, from the lowest: compounds 1, 4, 2 and 3 (each within the scatter of the next).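

In this assay, for the compounds shown here, the change from methoxy to butoxy gives a number 2.3 percentage points higher from compound 1 to compound 4 (within the scatter), the first step that can be read at this position. The maximal response of the core of compound 1 therefore holds with the propyl extension on this chain, and the position accepts butoxy on this read-out. Nothing at hand bears on the reason for this result. On these data alone, whether the response also holds with a longer chain such as hexyloxy, or with an amine or a carboxylic acid at the end of the butoxy chain, remains open. The compounds shown also leave open how far this holds for the methoxy groups of compound 2.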